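Nitro-to-methyl swap on the aryl arm of compound 1

The compounds below may be only part of what the source reports. "The series", "measured", "known", "first", "only" and "open" are said of these compounds alone.

Measured so far:
compound 1, `COc1ccc2cc(C(C)c3nnc4n3N=C(c3ccc([N+](=O)[O-])cc3)CS4)ccc2c1`: 15100 nM
compound 2, `COc1ccc(C2=Nn3c(nnc3C(C)c3ccc(-c4ccccc4)c(F)c3)SC2)cc1`: 4400 nM

Both compounds were run in a functional assay on HCT-116 cells (Homo sapiens) for inhibition, read by sulforhodamine B assay, with a stated time of 72 h; a lower number here means a stronger inhibitor, a higher number a weaker inhibitor. Compound 1 gives the highest of the two numbers; compound 2 sits at the lower number, and the gap between them is beyond the scatter, but the two structures differ in several places at once, so no single step can be read from that pair.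

The next compound keeps the core of compound 1 and changes one site. Compound 3 is `COc1ccc2cc(C(C)c3nnc4n3N=C(c3ccc(C)cc3)CS4)ccc2c1`. The change is methyl in place of nitro on an aromatic carbon, sitting para to a large group on a six-membered aromatic ring of carbon only. Within the data shown here, no step between measured compounds covers this exchange, so nothing in the data fixes its direction or size.

Among the measured compounds shown here, with no matching step available, the expectation is a step from compound 1 to compound 3 of a 1.3-fold lower number from compound 1 to compound 3 (0.10 log units; within the scatter) in this assay, not clearly beyond the scatter in either direction. Compound 3 is accordingly estimated at 12000 nM, with a range from 4000 nM to 40000 nM.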

Compound 3, half-maximal inhibitory concentration: 10200 nM
Estimate against measurement, compound 3: 1.2-fold (0.07 log units) above; the measured number falls inside the stated range.
By their numbers in this assay, from the lowest: compound 2; then compounds 3 and 1 (each within the scatter of the next).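

In this assay, among these compounds, the exchange of 4-nitrophenyl for 4-methylphenyl is the first single-site step, and it is a small one (a 1.5-fold lower number from compound 1 to compound 3 (0.17 log units; within the scatter)). This position on the aromatic ring therefore tolerates methyl in place of nitro without a shift beyond the scatter, even though the two groups differ in heavy atoms and only the nitro carries hydrogen-bond acceptors, so the read-out at this site does not depend on the nitro group in this pair. No measurement of any property or other supporting data bears on this result.

On these data alone, whether a different kind of group at this site, such as an amine, a carboxylic acid or a longer chain, would move the number beyond the scatter remains open. Among the compounds shown here, also open is whether the same exchange would read alike with the other arm of compound 2, since the gap between compound 1 and compound 2 spans several sites and gives no single step.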